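The source may hold more compounds than are shown below. What is called first, only, known or untested is meant among the compounds shown, and "the series" means these compounds.

Measured so far, in a functional assay on SK-OV-3 cells (Homo sapiens) for inhibition, read by sulforhodamine B assay, with a stated time of 48 h; a lower number here means a stronger inhibitor of growth, a higher number a weaker inhibitor of growth:
Compound 1, `COc1cc(-c2cc(/C=C/C(=O)c3ccc(Cl)c(Cl)c3)[nH]n2)cc(OC)c1OC`: 18800 nM
Compound 2, `COc1ccc(C(=O)/C=C/c2cc(-c3cc(OC)c(OC)c(OC)c3)n[nH]2)cc1`: 20500 nM

The two measured compounds share the same core and differ only in the ring attached to the carbonyl carbon. Compound 1 gives the smaller of the two numbers, but the step of a 1.1-fold higher number from compound 1 to compound 2 (0.04 log units; within the scatter) lies within the scatter, so the two compounds cannot be separated on these data.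

Compound 3, `COc1cc(-c2cc(/C=C/C(=O)c3ccc(F)c(F)c3)[nH]n2)cc(OC)c1OC`, has not yet been measured in this assay. It differs from compound 1 in one place: 3,4-difluorophenyl in place of 3,4-dichlorophenyl on a carbonyl carbon. Going by the values given here, the only measured step at the carbonyl carbon, a 1.1-fold higher number from compound 1 to compound 2 (0.04 log units; within the scatter), exchanged the whole ring for a quite different one and produced no movement beyond the scatter. Among the compounds with values here, that is the sole evidence bearing on the change to compound 3, and it gives no reason to expect a step larger than the scatter in either direction. For compound 3 the expected value in this assay is therefore 22000 nM, with a range from 9000 nM to 55000 nM. The step of a 1.2-fold higher number from compound 1 to compound 3 (0.07 log units; within the scatter) implied by this estimate is expected to stay within the usual scatter.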

Compound 3, concentration for total growth inhibition: 58600 nM
Estimate against measurement, compound 3: 2.7-fold (0.43 log units) below; the measured number lies above the stated range.
By their numbers in this assay, from the lowest: compounds 1 and 2 (each within the scatter of the next); then compound 3.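

Within this assay, the ring on the carbonyl carbon can move the number after all: the earlier exchange (a 1.1-fold higher number from compound 1 to compound 2 (0.04 log units; within the scatter)) stayed within the scatter, but 3,4-difluorophenyl in place of 3,4-dichlorophenyl gives a modest step towards weaker inhibition of growth (a 3.1-fold higher number from compound 1 to compound 3 (0.49 log units; beyond the scatter)). The same ring also stands apart from 4-methoxyphenyl (a 2.9-fold higher number from compound 2 to compound 3 (0.46 log units; beyond the scatter)), so the two rings that look least alike here gave numbers within the scatter of each other, while two rings with the same count of heavy atoms, differing only in fluorine against chlorine, did not. Nothing among the data shown accounts for this step.

With only three rings shown on this carbonyl carbon, these results cannot say whether the number depends on the halogen itself or would also move with other groups on the ring, such as an amine or a carboxylic acid. Going by these compounds, it also remains open how a longer chain in place of the ring would fare, and whether the same exchange of chlorine for fluorine would give a similar step on a different core.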